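A few compounds are considered here, and "the series" means these few. Any claim that something is new, unique, unknown or untested is made for them only; others in the source may bear on it.

Working notes on the series. Within the data shown here, in an ADME assay on a cell-free system (plasma, Homo sapiens), with a stated time of 30 min (a higher number here means that more of the compound is left, a lower number that less of the compound is left), compound 1 `CCCOc1ccccc1C(=O)N[C@]1(OC)C(=O)N2C(C(=O)OCc3ccc(C(=O)O)cc3)=C(CSc3nnnn3C)CO[C@@H]21` gives 26%, and compound 2 `CO[C@@]1(NC(=O)c2ccccc2OC(C)C)C(=O)N2C(C(=O)OCc3ccc(C(=O)O)cc3)=C(CSc3nnnn3C)CO[C@@H]21` gives 42%, the higher of the two numbers so far. Compound 3 `CCC(C)Oc1ccccc1C(=O)N[C@]1(OC)C(=O)N2C(C(=O)OCc3ccc(C(=O)O)cc3)=C(CSc3nnnn3C)CO[C@@H]21` differs from compound 2 as follows: methyl in place of hydrogen on a saturated chain carbon, two bonds along the chain from an oxygen on an aromatic ring. This is methyl in place of hydrogen on a saturated chain carbon, turning isopropoxy into sec-butoxy. Among the measured compounds shown here, the only measured step that bears on this is a number 16 percentage points higher from compound 1 to compound 2 (beyond the scatter), which swaps propyl for isopropyl on the same oxygen. That single modest step sets no direction, so no change beyond the scatter is expected in this assay, with an estimated a number 2 percentage points higher from compound 2 to compound 3 (within the scatter). Compound 3 is expected at 44%, within 30% to 58%.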

Compound 3, percent of the compound remaining: 39%
Estimate against measurement, compound 3: 5 percentage points above; low and high end bracket the measured number.
By their numbers in this assay, from the lowest: compound 1; then compounds 3 and 2 (each within the scatter of the next).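

In this assay, extending isopropoxy to sec-butoxy gives a number 3 percentage points lower from compound 2 to compound 3 (within the scatter), so this position takes the added methyl without a change beyond the scatter. Methyl on the saturated chain carbon bound to the oxygen gives a number 13 percentage points higher from compound 1 to compound 3 (beyond the scatter), so both branched ethers, compound 2 and compound 3, stand apart from the propoxy of compound 1. No measurement shown accounts for these numbers. Open, going by these compounds, is whether tert-butoxy or a longer chain such as 2-pentyloxy would hold this level, and whether an amine on the chain would alter it.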